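Triaryl hydroxyphenyl series: cytotoxicity on prostate carcinoma cells

The source may hold more compounds than are shown below. What is called first, only, known or untested is meant among the compounds shown, and "the series" means these compounds.

Measured compounds:
compound 1, `Oc1ccc(-c2cc(-c3ccc(O)cc3)nc(-c3ccc(O)cc3)c2)cc1`, 3160 nM
compound 2, `Oc1ccc(-c2cc(-c3cccc(O)c3)cc(-c3cccc(O)c3)n2)cc1`, 1940 nM

In a functional assay on DU-145 cells (Homo sapiens) for cytotoxicity, read by CCK-8 assay, with a stated time of 4 days (on this read-out lower numbers stand for stronger inhibition and higher numbers for weaker inhibition), compound 1 gives 3160 nM and compound 2 gives 1940 nM. Compound 2 holds the lower of the two numbers, but its gap to compound 1 is within the scatter, so the two compounds cannot be told apart on these data. Among the compounds with values here, no step between measured compounds that differ in one place has been measured.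

Compound 3, `Oc1ccc(-c2cc(-c3cccc(O)c3)cc(-c3ccc(O)cc3)n2)cc1`, is not yet measured. It differs from compound 2 by 4-hydroxyphenyl in place of 3-hydroxyphenyl on an aromatic carbon. Compound 3 thereby lies between compound 2 and compound 1 in its pattern of hydroxyphenyl groups, and these two give values within the scatter of each other. The step from compound 2 to compound 3 in this assay is therefore expected to stay within the scatter, with no clear direction, as a 1.3-fold higher number from compound 2 to compound 3 (0.11 log units; within the scatter). For compound 3 the expected value is 2500 nM, with a range from 1000 nM to 6000 nM.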

Compound 3, half-maximal inhibitory concentration: 1400 nM
For compound 3 the middle estimate is 1.8-fold (0.25 log units) above the measured one; measured number inside the range.
By their numbers in this assay, from the lowest: compounds 3, 2 and 1 (each within the scatter of the next, the first and the last beyond it).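

Moving the hydroxyl of the aryl group on the aromatic carbon next to the ring nitrogen, with 4-hydroxyphenyl in place of 3-hydroxyphenyl, gives a 1.4-fold lower number from compound 2 to compound 3 (0.14 log units; within the scatter) in this assay and so does not separate the two groups at this position. Within the data shown here, the change of 4-hydroxyphenyl to 3-hydroxyphenyl on an aromatic carbon gives a 2.3-fold lower number from compound 1 to compound 3 (0.35 log units; beyond the scatter) and is the only step that clears the scatter, though it remains modest, so the hydroxyl pattern has at most a small bearing on this read-out. No data at hand explain either step.
Whether the hydroxyl itself is needed remains open, as the compounds shown carry no methoxy group, amine or carboxylic acid in its place. Also open, from the compounds shown here alone, is whether the series can move beyond this narrow band of values once the hydroxyphenyl rings are replaced, for instance by a pyridyl or an unsubstituted phenyl group.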